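Removing the Last Sulfonamide from the Shared Core

A few compounds are considered here, and "the series" means these few. Any claim that something is new, unique, unknown or untested is made for them only; others in the source may bear on it.

Among the compounds with values here, compound 2 `CS(=O)(=O)Nc1ccc(-c2nc3cc(NS(=O)(=O)c4ccc(Cl)s4)ccc3o2)cc1` gives 43000 nM in an assay on cells for inhibition of HSP60/HSP10 (Homo sapiens), with a stated time of 60 min (a higher number here means a weaker inhibitor, a lower number a stronger inhibitor), the highest of the two numbers measured so far. Compound 1 `O=S(=O)(Nc1ccc2oc(-c3ccc(NS(=O)(=O)c4cccc5nonc45)cc3)nc2c1)c1ccc(Cl)s1` gives 13000 nM. Within the data shown here, the one measured step, a 3.3-fold higher number from compound 1 to compound 2 (0.52 log units; beyond the scatter), shows that shrinking the group on that sulfonyl sulfur weakened inhibition. Compound 3 `O=S(=O)(Nc1ccc2oc(-c3ccccc3)nc2c1)c1ccc(Cl)s1` goes further in that direction: hydrogen in place of methanesulfonamido on an aromatic carbon. Because the step of a 3.3-fold higher number from compound 1 to compound 2 (0.52 log units; beyond the scatter) was only modest, a further modest weakening is expected rather than a large one. Compound 3 is therefore estimated at 80000 nM, with a range of 25000 nM to 250000 nM. The expected step is a 1.9-fold higher number from compound 2 to compound 3 (0.27 log units; within the scatter).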

Compound 3, half-maximal inhibitory concentration: 70000 nM
Estimate against measurement, compound 3: 1.1-fold (0.06 log units) above, and the stated range covers the measured number.
By their numbers in this assay, from the lowest: compound 1; then compounds 2 and 3 (each within the scatter of the next).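

With hydrogen in place of methanesulfonamido on this aromatic carbon, this assay gives a 1.6-fold higher number from compound 2 to compound 3 (0.21 log units; within the scatter), so the two numbers cannot be told apart. The earlier step changed only the group on the sulfonyl sulfur, so it could not show that this sulfonamide can be absent with no difference beyond the scatter. No supporting measurement is available to explain this result. Still open, from the compounds shown here alone, is whether any other group on this carbon would separate from these two compounds. An amine, a carboxylic acid or a longer chain here would test that.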